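This account rests on a few compounds, and the source may have more. Where it says the series, first, only, none or still open, it means among the compounds named here.

Working notes on the series. Compound 1 (`COc1cc2ncnc(-n3nc(-c4ccccn4)nc3N)c2cc1OCCCNC(=O)OC(C)(C)C`) and compound 2 (`COc1cc2ncnc(-n3nc(-c4ccccn4)nc3N)c2cc1OCCCCNC(=O)OC(C)(C)C`) share one core and differ only in the length of the chain ending in (tert-butoxycarbonyl)amino. In an ADME assay on BJ cells (Homo sapiens) for cytotoxicity, with a stated time of 72 h (on this read-out higher numbers stand for an effect only at larger amounts of compound and lower numbers for an effect already at smaller amounts), compound 1 gives > 12000 nM, which is a limit and not a number. Compound 2 gives > 7000 nM in this assay, and this too is only a limit. Compound 2 therefore stands on a limit, and no measured number in the series anchors it.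

Compound 3 (`COc1cc2ncnc(-n3nc(-c4ccccn4)nc3N)c2cc1OCCNC(=O)OC(C)(C)C`) changes the same chain: (tert-butoxycarbonyl)amino in place of 2-((tert-butoxycarbonyl)amino)ethyl on a saturated chain carbon, two bonds along the chain from an oxygen on an aromatic ring. Among the compounds with values here, the one measured step bearing on this change is a step that the two limits leave unreadable from compound 1 to compound 2. It gives neither a size nor a direction to carry over. With both neighbouring values being limits, no step beyond the scatter is expected in this assay, and no direction can be argued. The expected step is a step that the limit leaves unreadable from compound 2 to compound 3. For compound 3 the estimated value is 10000 nM, with an expected range from 5000 nM to 30000 nM, and a report of only a limit would be the likeliest outcome.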

Compound 3, half-maximal effective concentration: > 15000 nM
Compound 3 was reported as a limit; the forecaster's own chance of this, stated with the estimate: 80%; at least 1.5-fold (0.17 log units) between middle value and limit.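

In this assay, compound 1, compound 2 and compound 3 all stand on limits and not on numbers, so the steps among them cannot be read, in either size or direction. The compounds shown leave open whether the length of the chain ending in (tert-butoxycarbonyl)amino shifts the half-maximal effective concentration at all.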